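Thiophen-2-yl in place of 2,5-dimethylthiophen-3-yl

This account rests on a few compounds, and the source may have more. Where it says the series, first, only, none or still open, it means among the compounds named here.

Among the measured compounds shown here, in a functional assay on cells (Cancer cell lines, Homo sapiens) for inhibition (on this read-out lower numbers stand for stronger inhibition of growth and higher numbers for weaker inhibition of growth), compound 1 (`Cc1cc(-c2nc3sc(C)cn3c2/C=N/NC(=N)N)c(C)s1`) gives 11700 nM as the lower of the two numbers so far, and compound 2 (`Cc1cc(-c2nc3sccn3c2/C=N/NC(=N)N)c(C)s1`) gives 32400 nM against that. Compound 3 (`Cc1cn2c(/C=N/NC(=N)N)c(-c3cccs3)nc2s1`) keeps the core of compound 1 but carries thiophen-2-yl in place of 2,5-dimethylthiophen-3-yl on an aromatic carbon. For the measured compounds named here, the only measured step (a 2.8-fold higher number from compound 1 to compound 2 (0.44 log units; beyond the scatter)) is hydrogen in place of methyl at another place, so it bears only indirectly. No measurement covers the place changed here. A modest step to a higher number in this assay is still expected. The expected step is a 1.9-fold higher number from compound 1 to compound 3 (0.27 log units; within the scatter) on this estimate. For compound 3 the estimated value is 22000 nM with an expected range from 9000 nM to 55000 nM in this read-out.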

Compound 3, concentration for total growth inhibition: 8130 nM
Compound 3: middle estimate off by 2.7-fold (0.43 log units), on the high side; measured number below the stated range.
By their numbers in this assay, from the lowest: compounds 3 and 1 (each within the scatter of the next); then compound 2.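

In this assay, among the compounds shown here, thiophen-2-yl in place of 2,5-dimethylthiophen-3-yl gives a 1.4-fold lower number from compound 1 to compound 3 (0.16 log units; within the scatter) at this place, the first reading here, as the earlier step concerned another place. The two methyl groups and the change of attachment on the thiophene, taken together, therefore give no step beyond the scatter on the shared core. Nothing available bears on the reason for this result.

Still open, on these data alone, is whether the step of hydrogen in place of methyl carries over to the thiophen-2-yl compounds. Also open, as far as these compounds go, is whether an amine or a carboxylic acid at this place moves the number beyond the scatter.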